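The source may hold more compounds than are shown below. What is called first, only, known or untested is meant among the compounds shown, and "the series" means these compounds.

Measured so far in a functional assay on CHO-K1 cells for antagonist activity at C-X-C chemokine receptor type 3 (Homo sapiens), read by FLIPR and calcium flux; a higher number here means a weaker inhibitor, a lower number a stronger inhibitor:
- compound 1 `C[C@@H]1CN(c2ccc(C(F)(F)F)cn2)[C@@H](C)CN1S(=O)(=O)C[C@]12CC[C@H](CC1=O)C2(C)C` gives 6310 nM
- compound 2 `C[C@H]1CN(S(=O)(=O)C[C@]23CC[C@H](CC2=O)C3(C)C)CCN1c1ccc(C(F)(F)F)cn1` gives 158 nM
- compound 3 `C[C@@H]1CN(S(=O)(=O)C[C@]23CC[C@H](CC2=O)C3(C)C)CCN1c1ccc(C(F)(F)F)cn1` gives 501 nM

Compound 2 stands lowest of the three numbers in this assay. Its nearest neighbour is compound 3, and the step of a 3.2-fold higher number from compound 2 to compound 3 (0.50 log units; beyond the scatter) rests only on the configuration drawn at one saturated ring carbon (the fact that compounds 2 and 3 differ only in the configuration as drawn). The step of a 40-fold lower number from compound 1 to compound 2 (1.60 log units; beyond the scatter) is far larger and removes a methyl from a saturated ring carbon of the shared core.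

Compound 4 `C[C@H]1CN(S(=O)(=O)C[C@]23CC[C@H](CC2=O)C3(C)C)CCN1c1ncc(C(F)(F)F)cn1` is the unmeasured member. It differs from compound 2 by 5-(trifluoromethyl)pyrimidin-2-yl in place of 5-(trifluoromethyl)pyridin-2-yl on an amine nitrogen in a ring. Neither measured step touches the aromatic group on the ring amine nitrogen: one concerns a methyl on the saturated ring, the other the configuration at a saturated ring carbon. For the measured compounds named here, there is therefore no step from which the size of this change can be read off directly. With the saturated ring of compound 2 kept unchanged, the expectation is a step within or only slightly beyond the scatter, and if anything toward a higher number.

The estimate for compound 4 in this assay is 250 nM, with a range from 80 nM to 800 nM, which is expected to mean a step of a 1.6-fold higher number from compound 2 to compound 4 (0.20 log units; within the scatter).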

Compound 4, half-maximal inhibitory concentration: 126 nM
Compound 4: the middle estimate sits 2.0-fold (0.30 log units) above what was measured, within the range that was stated.
By their numbers in this assay, from the lowest: compounds 4 and 2 (each within the scatter of the next); then compound 3; then compound 1.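

For the compounds shown here, exchanging 5-(trifluoromethyl)pyridin-2-yl for 5-(trifluoromethyl)pyrimidin-2-yl on an amine nitrogen in a ring is the first change at this aromatic group, and in this assay it reads a 1.3-fold lower number from compound 2 to compound 4 (0.10 log units; within the scatter). Compounds 2 and 4 therefore cannot be told apart in this assay, so at this position the pair tolerates a ring with 2 hetero atoms in place of a ring with 1 hetero atom, and 2 hydrogen-bond acceptors in place of 1, whereas both earlier steps, made on the saturated ring, lie beyond the scatter. Nothing available here bears on why these two aromatic groups read alike.

This single pair does not show whether the same exchange would read alike with the other configuration of compound 3 or the additional ring methyl of compound 1. It also leaves open how the position responds to a larger departure, such as a plain phenyl ring, a pyrazin-2-yl ring, or a chlorine or nitrile in place of the trifluoromethyl.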